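Removing the Large Substituent: Weak Cytotoxicity Expected

The source may report more compounds than this note shows. Statements on the series, on what has been measured and on what is new or still open speak of the compounds shown alone.

Compound 1, `Cc1ccc(S(=O)(=O)NCc2cn(C[C@H](O)[C@H]3OC(=O)C(OCc4ccccc4)=C3OCc3ccccc3)nn2)cc1`: 50 nM
Compound 2, `C[Si](C)(C)c1cn(C[C@H](O)[C@H]2OC(=O)C(OCc3ccccc3)=C2OCc2ccccc2)nn1`: 20000 nM
Compound 3, `CCCCCc1ccc(-c2cn(C[C@H](O)[C@H]3OC(=O)C(OCc4ccccc4)=C3OCc3ccccc3)nn2)cc1`: > 100000 nM

The three compounds share one core and differ only in the group on one aromatic carbon. In an ADME assay on HFF cells (Homo sapiens) for cytotoxicity, read by MTT assay, with a stated time of 72 h (on this read-out lower numbers stand for stronger inhibition and higher numbers for weaker inhibition), compound 1 gives 50 nM and compound 2 gives 20000 nM. For compound 3 the assay reports only a limit, > 100000 nM. Compound 3 thus stands at the weakest end of the numbers shown, at the limit of > 100000 nM in this assay, at which 1 of the 3 values shown sits.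

Compound 4, `O=C1O[C@H]([C@@H](O)Cn2ccnn2)C(OCc2ccccc2)=C1OCc1ccccc1`, carries hydrogen in place of 4-pentylphenyl on an aromatic carbon. The steps bearing on this change are an at least 5.0-fold higher number from compound 2 to compound 3 (0.69 log units; beyond the scatter) and an at least 2000-fold higher number from compound 1 to compound 3 (3.30 log units; beyond the scatter), in both of which the 4-pentylphenyl compound holds the highest number. Removing that group is therefore expected to lower the number, though the small group of compound 2 suggests the drop stays modest. Compound 4 is expected to move by an at least 2.5-fold lower number from compound 3 to compound 4 (0.39 log units; beyond the scatter). The estimate for compound 4 is 40000 nM, between 10000 nM and 150000 nM.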

Compound 4, half-maximal inhibitory concentration: 610 nM
Compound 4: middle estimate off by 66-fold (1.82 log units), on the high side; the measured number lies below the stated range.
By their numbers in this assay, from the lowest: compound 1; then compound 4; then compound 2. At a limit, above all of these: compound 3.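

Hydrogen on this aromatic carbon gives an at least 160-fold lower number from compound 3 to compound 4 (2.21 log units; beyond the scatter) and, in place of the silicon-bearing group, a 33-fold lower number from compound 2 to compound 4 (1.52 log units; beyond the scatter), so the unsubstituted position is far from the weak end and both of these groups raise the number. Only the (((4-methylphenyl)sulfonyl)amino)methyl group lowers it, as hydrogen in its place gives a 12-fold higher number from compound 1 to compound 4 (1.09 log units; beyond the scatter). The number for compound 3 remains a limit: the limit of > 100000 nM in this assay, at which 1 of the 4 values shown sits.

Going by these compounds, whether an amine or a carboxylic acid on this carbon would lower the number stays open. So does whether a pentyl chain without the phenyl ring would raise it.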